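Shortening the amide chain toward a branched tert-butyl group

The source may hold more compounds than are shown below. What is called first, only, known or untested is meant among the compounds shown, and "the series" means these compounds.

Three measured compounds share one core and differ in the acyl chain on the amide and in one aromatic substituent. Compound 1 `CCC(=O)Nc1ccc(S(=O)(=O)Oc2ccccc2C(C)C)cc1` gives 11000 nM in a functional assay on M21 cells (Homo sapiens) for antiproliferative activity, read by sulforhodamine B assay, with a stated time of 48 h; a higher number here means a weaker inhibitor, a lower number a stronger inhibitor. Compound 2 `CCCCCC(=O)Nc1ccc(S(=O)(=O)Oc2ccccc2C(C)C)cc1` gives 6700 nM in this assay, and compound 3 `CCCCCC(=O)Nc1ccc(S(=O)(=O)Oc2ccccc2I)cc1` gives 11000 nM. Compound 2 has the lowest number of the three, yet both its neighbours sit close: a 1.6-fold lower number from compound 1 to compound 2 (0.22 log units; within the scatter), and a 1.6-fold higher number from compound 2 to compound 3 (0.22 log units; within the scatter). Nothing separates these compounds beyond the usual scatter.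

Compound 4 `CC(C)c1ccccc1OS(=O)(=O)c1ccc(NC(=O)C(C)(C)C)cc1` is not yet measured. Compared with compound 2 the change is tert-butyl in place of pentyl on a carbonyl carbon. Going by the values given here, the only measured step at the same place is the one from compound 1 to compound 2, which altered the chain on the carbonyl carbon and stayed within the scatter. Among the compounds with values here, no measured step informs about branching there. The expectation for compound 4 in this assay is therefore a step of a 1.3-fold higher number from compound 2 to compound 4 (0.13 log units; within the scatter), no larger than the scatter, leaning slightly toward a higher number because a 1.6-fold lower number from compound 1 to compound 2 (0.22 log units; within the scatter) ran the other way on chain growth. Compound 4 is thus estimated at 9000 nM, between 4000 nM and 20000 nM.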

Compound 4, half-maximal inhibitory concentration: 6200 nM
For compound 4 the middle estimate is 1.5-fold (0.16 log units) above the measured one; low and high end bracket the measured number.
By their numbers in this assay, from the lowest: compounds 4, 2, 1 and 3 (each within the scatter of the next).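

Branching on this carbonyl carbon is now tested for the first time: tert-butyl in place of pentyl gives a 1.1-fold lower number from compound 2 to compound 4 (0.03 log units; within the scatter) and tert-butyl in place of ethyl gives a 1.8-fold lower number from compound 1 to compound 4 (0.25 log units; within the scatter) in this assay. Neither step is larger than the scatter, so a branched chain and a straight chain of either length cannot be told apart here, and no size or shape of acyl chain among these compounds stands out. Nothing available explains this lack of difference.

Still open, on these data alone, is whether a different group on this carbonyl carbon, such as a much longer chain like decyl, a phenyl ring, or a chain ending in an amine or a carboxylic acid, would shift the number beyond the scatter. Also open, as far as these compounds go, is whether tert-butyl would give a similar number with iodo in place of isopropyl.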